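Replacing the Aryl Group of Compound 3 with Another

The source may report more compounds than this note shows. Statements on the series, on what has been measured and on what is new or still open speak of the compounds shown alone.

Of the compounds shown here, three sharing one core have been measured in an in vitro functional assay on cells for agonist activity at Bombesin receptor subtype-3 (Homo sapiens), read by luminescence and calcium flux; on this read-out lower numbers stand for an effect already at smaller amounts and higher numbers for an effect only at larger amounts of compound. Compound 1 `O=C(O)c1ccccc1-c1ccc(CCc2ncc(CC3CCC3)[nH]2)cc1` gives 588 nM. Compound 2 `O=C(O)c1ccccc1-c1ccc(CCc2ncc(CC3CCOCC3)[nH]2)cc1` gives 338 nM in this assay. Compound 3 `O=C(O)c1ccccc1-c1ccc(CCc2ncc(Cc3ccc(F)cc3)[nH]2)cc1` gives 1600 nM, the highest number of the three. The step of a 1.7-fold lower number from compound 1 to compound 2 (0.24 log units; within the scatter) stays within the usual scatter, whereas a 2.7-fold higher number from compound 1 to compound 3 (0.43 log units; beyond the scatter) and a 4.7-fold higher number from compound 2 to compound 3 (0.68 log units; beyond the scatter) both lie beyond it; within this small set, both saturated rings give lower numbers than the 4-fluorophenyl group.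

Compound 4 `COc1ccccc1Cc1cnc(CCc2ccc(-c3ccccc3C(=O)O)cc2)[nH]1` differs from compound 3 in one place: 2-methoxyphenyl in place of 4-fluorophenyl on a saturated chain carbon bound to an aromatic carbon. Among the measured compounds shown here, no measured pair shows one aromatic ring replaced by another, so none of the three steps bears directly on this change; the steps from compound 1 and from compound 2 to compound 3 show only that the 4-fluorophenyl group gives the highest number of the series, and give no direction for a move to 2-methoxyphenyl. For compound 4 the change is therefore expected to produce a step of about a 1.3-fold lower number from compound 3 to compound 4 (0.12 log units; within the scatter) in this assay, a size that stays within the scatter. Compound 4 is thus estimated to give 1200 nM in this assay, with a range from 400 nM to 4000 nM.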

Compound 4, half-maximal effective concentration: 1720 nM
The estimate for compound 4 lay 1.4-fold (0.16 log units) below the measured number, within the range that was stated.
By their numbers in this assay, from the lowest: compounds 2 and 1 (each within the scatter of the next); then compounds 3 and 4 (each within the scatter of the next).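

Among the compounds shown here, at this position, on a saturated chain carbon bound to an aromatic carbon, 2-methoxyphenyl in place of 4-fluorophenyl gives a 1.1-fold higher number from compound 3 to compound 4 (0.03 log units; within the scatter) in this assay and so provides the one pair of aromatic rings in the set, which the read-out does not separate even though the entering group counts one hydrogen-bond acceptor and the leaving group none. The gap to the saturated rings also holds for this second aromatic ring, with a 5.1-fold higher number from compound 2 to compound 4 (0.71 log units; beyond the scatter) for oxan-4-yl and a 2.9-fold higher number from compound 1 to compound 4 (0.47 log units; beyond the scatter) for cyclobutyl as the corresponding steps. Among these four compounds, both saturated rings therefore give lower numbers than both aromatic rings, with no compound going against this, although it rests on only two rings of each kind. Nothing at hand gives a reason for this split.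

In the pair of compound 3 and compound 4, the substituent and its place on the ring change together, so the compounds shown leave open how 2-fluorophenyl, 4-methoxyphenyl or plain phenyl would read. They also leave open whether an amine on a saturated ring at this position would follow the saturated rings or depart from them.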